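The source may report more compounds than this note shows. Statements on the series, on what has been measured and on what is new or still open speak of the compounds shown alone.

Compound 1, `COc1nc(-c2ccc(C#N)cc2)ccc1[C@@H](c1ccccc1)[C@@](O)(CCN(C)C)c1cccc2ccccc12`: in a toxicity assay on Vero cells (Chlorocebus sabaeus) for cytotoxicity (a lower number here means that less compound is tolerated, a higher number that more compound is tolerated), compound 1 gives > 50 ug/mL, which is a limit of the assay. Compound 2, `COc1nc(-c2ccccc2F)ccc1[C@@H](c1ccccc1)[C@@](O)(CCN(C)C)c1cccc2ccccc12`: compound 2 gives > 50 ug/mL, again a limit. Compound 3, `COc1ccc(-c2ccc([C@@H](c3ccccc3)[C@@](O)(CCN(C)C)c3cccc4ccccc34)c(OC)n2)cc1`: compound 3 gives > 50 ug/mL, also a limit.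

Compound 1 thus stands only at a limit, as do the other two values shown. Compound 4, `COc1nc(-c2ccsc2)ccc1[C@@H](c1ccccc1)[C@@](O)(CCN(C)C)c1cccc2ccccc12`, differs from compound 1 in one place: thiophen-3-yl in place of 4-cyanophenyl on an aromatic carbon. The measured steps that touch this aromatic carbon are a step that the two limits leave unreadable from compound 1 to compound 2, a step that the two limits leave unreadable from compound 1 to compound 3 and a step that the two limits leave unreadable from compound 2 to compound 3; none can be sized because of the limit of > 50 ug/mL in this assay, at which 3 of the 3 values shown sit. No step beyond the scatter can be read from them, so none is expected here either. Compound 4 is expected to sit around 60 ug/mL, within 30 ug/mL to 150 ug/mL, most likely reported as a limit again. This expectation means a step that the limit leaves unreadable from compound 1 to compound 4.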

Compound 4, half-maximal cytotoxic concentration: 24.4 ug/mL
The estimate for compound 4 lay 2.5-fold (0.39 log units) above the measured number; measured number below the stated range.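

The three phenyl groups gave no readable step at this aromatic carbon in this assay, but the position does respond to what it carries: thiophen-3-yl gives an at least 2.0-fold lower number from compound 1 to compound 4 (0.31 log units; beyond the scatter), an at least 2.0-fold lower number from compound 3 to compound 4 (0.31 log units; beyond the scatter) and an at least 2.0-fold lower number from compound 2 to compound 4 (0.31 log units; beyond the scatter). Each step is a minimum, and its true size cannot be read, because each starts from a limit: the limit of > 50 ug/mL in this assay, at which 3 of the 4 values shown sit.

On these data alone, whether the lower number follows from the five-membered ring or from its sulfur remains open, and a furan-3-yl group at this carbon would help separate the two. As far as these compounds go, how an amine would fare here is also open.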